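The compounds below may be only part of what the source reports. "The series", "measured", "known", "first", "only" and "open" are said of these compounds alone.

Measured compounds in a physicochemical assay for solubility, read by mass spectrometry, in phosphate buffer, with a stated time of 24 h, at pH 7.4; a lower number here means a less soluble compound, a higher number a more soluble compound:
compound 1 `O=C(Nc1ccc(C(F)(F)F)cc1)NC1CCN(C(=O)C2=COCC2)CC1` gives 2.3 ug/mL
compound 2 `O=C(Nc1ccc(C(F)(F)F)cc1)NC1CCN(C(=O)c2ccoc2)CC1` gives 2.2 ug/mL

Of the two numbers, compound 1 is the higher as written, but the step of a 1.0-fold lower number from compound 1 to compound 2 (0.02 log units; within the scatter) lies within the scatter, so no order between the two compounds is claimed. That single measured step swaps a five-membered aromatic ring for a five-membered non-aromatic ring on a carbonyl carbon and says nothing about the far aryl end of the shared core.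

Compound 3 `O=C(Nc1ccc(OC(F)(F)F)cc1)NC1CCN(C(=O)C2=COCC2)CC1` is not yet measured. It differs from compound 1 by trifluoromethoxy in place of trifluoromethyl on an aromatic carbon. No measured step touches this change, so no bearing can be drawn from the one step shown; the only guide is that the one change made so far left this assay unmoved. A step of a 1.1-fold higher number from compound 1 to compound 3 (0.04 log units; within the scatter) is therefore expected, within the scatter. Compound 3 is estimated at 2.5 ug/mL, with a range from 1 ug/mL to 6 ug/mL.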

Compound 3, solubility: 11 ug/mL
Compound 3: middle estimate off by 4.4-fold (0.64 log units), on the low side; measured number outside the range, above it.
By their numbers in this assay, from the lowest: compounds 2 and 1 (each within the scatter of the next); then compound 3.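

In this assay, the aryl end of the shared core responds where the carbonyl end did not: trifluoromethoxy in place of trifluoromethyl on an aromatic carbon, para to a large group, gives a 4.8-fold higher number from compound 1 to compound 3 (0.68 log units; beyond the scatter) and lies beyond the scatter. The ring change on the carbonyl carbon reads a 1.0-fold lower number from compound 1 to compound 2 (0.02 log units; within the scatter) and lies within it. This position is therefore the first in the series with a measured step beyond the scatter, though that rests on one pair, compared with the five-membered non-aromatic ring in place. No measured property of either group accompanies this step, so the data give no account of it.

Going by these compounds, it remains open whether the step carries over to the five-membered aromatic ring of compound 2. Also open, on these data alone, is how a methoxy, a nitrile or an amine would read at this same position.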